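Cytotoxicity notes on the shared core, compound 2 to compound 4

The source may report more compounds than this note shows. Statements on the series, on what has been measured and on what is new or still open speak of the compounds shown alone.

Compound 1 `Nc1nc(NC2CC2)c2ncn(/C=C3/CC3(CO)CO)c2n1`, compound 2 `CCCSc1nc(N)nc2c1ncn2/C=C1/CC1(CO)CO` and compound 3 `CCCCCCCCSc1nc(N)nc2c1ncn2/C=C1/CC1(CO)CO` share one core. In an ADME assay on Akata cells (Homo sapiens) for cytotoxicity, with a stated time of 7 days (a higher number here means that more compound is tolerated, a lower number that less compound is tolerated), compound 1 gives only a limit, > 20000 nM. Compound 2 likewise reaches only the limit, > 20000 nM. Compound 3 also stops at the limit, > 20000 nM. The steps a step that the two limits leave unreadable from compound 1 to compound 2, a step that the two limits leave unreadable from compound 1 to compound 3 and a step that the two limits leave unreadable from compound 2 to compound 3 therefore carry no readable size; all three values sit at the limit of > 20000 nM in this assay, at which 3 of the 3 values shown sit. Compound 4 `CC(C)Sc1nc(N)nc2c1ncn2/C=C1/CC1(CO)CO` differs from compound 2 by isopropyl in place of propyl on a sulfur. Of the measured steps, those altering the sulfur substituent bear on this change, and none shows a readable size, so no step beyond the scatter is expected in this assay. Compound 4 is expected to sit at the limit again, estimated at 20000 nM with range 10000 nM to 40000 nM. The step of a number no higher from compound 2 to compound 4 (the limit leaves the size open) is thus expected to be none beyond the scatter.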

Compound 4, half-maximal cytotoxic concentration: > 20000 nM
Compound 4: no number, only a limit; the forecaster's own chance of this, stated with the estimate: 85%; the middle value sits exactly at the limit.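

Compound 4 gives only a limit in this assay, > 20000 nM, so its steps to compound 1, compound 2 and compound 3 cannot be read. The compounds shown leave open whether any of these substituents changes the half-maximal cytotoxic concentration: the limit of > 20000 nM in this assay, at which 4 of the 4 values shown sit.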